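A few compounds are considered here, and "the series" means these few. Any claim that something is new, unique, unknown or untested is made for them only; others in the source may bear on it.

Compound 1, `Cc1nnc(-c2cccc(-c3ccc(C(=O)N(Cc4cccc(OCCCCCC(=O)O)c4)C(C)C)cc3)c2)o1`: in an ADME assay on HepG2 cells (Homo sapiens) for cytotoxicity, read by CellTiter-Glo and resazurin assay, with a stated time of 72 h (a higher number here means that more compound is needed for the effect, a lower number that less compound is needed), compound 1 gives > 26000 nM, which is a limit of the assay and not a number.
Compound 2, `CC(C)N(Cc1cccc(OCCCCCC(=O)O)c1)C(=O)c1ccc(-c2cccc(C(F)(F)F)c2)cc1`: in this assay compound 2 gives > 26000 nM, again a limit rather than a number.

Compound 2 therefore stands only at a limit in this assay, with no measured number of its own. Among the measured compounds shown here, the one other measured compound sits in the same place: the limit of > 26000 nM in this assay, at which 2 of the 2 values shown sit. For the measured compounds named here, the single step that joins the two measured compounds is a step that the two limits leave unreadable from compound 1 to compound 2, so it yields no readable size in either direction.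

Compound 3, `CC(C)N(Cc1cccc(OCCCCCC(=O)O)c1)C(=O)c1ccc(-c2ccc(Cl)c(Cl)c2)cc1`, differs from compound 2 in one place: 3,4-dichlorophenyl in place of 3-(trifluoromethyl)phenyl on an aromatic carbon. Going by the values given here, only the step from compound 1 to compound 2 bears on a change at this spot, and its size could not be read. The expectation for compound 3 in this assay is accordingly no step beyond the scatter, a step that the limit leaves unreadable from compound 2 to compound 3, with the result most likely again reported as a limit. Compound 3 is estimated at 40000 nM, within a range from 15000 nM to 100000 nM.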

Compound 3, half-maximal effective concentration: > 26000 nM
Compound 3 ended at the assay's limit; the forecaster's own chance of this, stated with the estimate: 80%; the middle value does not contradict the limit.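

The steps from compound 1 and compound 2 to compound 3 cannot be read, because all three compounds end at a limit of the assay and not at a number: the limit of > 26000 nM in this assay, at which 3 of the 3 values shown sit.

The compounds shown leave open where the true half-maximal effective concentration of each lies, and so whether the groups at this spot differ at all in this assay.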